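The source may report more compounds than this note shows. Statements on the series, on what has been measured and on what is new or still open speak of the compounds shown alone.

Measured so far in a functional assay on MCF7 cells (Homo sapiens) for inhibition, read by MTT assay, with a stated time of 48 h; a higher number here means a weaker inhibitor, a lower number a stronger inhibitor
compound 1 `c1ccc(-c2ccnc3c2c(-c2ccccc2)nn3-c2ccccc2)cc1` gives 28200 nM
compound 2 `Clc1ccc(-c2ccnc3c2c(-c2ccccc2)nn3-c2ccccc2)cc1` gives 61100 nM

Compound 2 holds the highest of the two numbers, and its nearest neighbour is compound 1, which stands lower by a margin beyond the scatter. The next change leads from compound 2 to compound 3 (`Cc1ccc(-c2ccnc3c2c(-c2ccccc2)nn3-c2ccccc2)cc1`) and reads as follows (methyl in place of chloro on an aromatic carbon), that is, methyl in place of chloro on an aromatic carbon, para to a large group. For the measured compounds named here, only one measured step bears on it, the modest one with chloro in place of hydrogen on an aromatic carbon (a 2.2-fold higher number from compound 1 to compound 2 (0.34 log units; beyond the scatter)). Going by the values given here, no measured step involves methyl, so the direction rests on the loss of chloro alone, and the size is uncertain. A modest step toward a lower number is expected in this assay, possibly no larger than the scatter, which would place compound 3 near compound 1 (28200 nM). The estimated step is a small one (a 1.7-fold lower number from compound 2 to compound 3 (0.24 log units; within the scatter)). For compound 3 the estimated value is 35000 nM with an expected range from 16000 nM to 75000 nM in repeated measurement.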

Compound 3, half-maximal inhibitory concentration: 5590 nM
The estimate for compound 3 lay 6.3-fold (0.80 log units) above the measured number, and the stated range ends above it.
By their numbers in this assay, from the lowest: compound 3; then compound 1; then compound 2.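

In this assay, the place on the aromatic ring para to a large group proves far more responsive than the earlier pair suggested: replacing chloro with methyl gives an 11-fold lower number from compound 2 to compound 3 (1.04 log units; beyond the scatter), a large step for an exchange of one heavy atom for another. Methyl also separates from the unsubstituted parent, with a 5.0-fold lower number from compound 1 to compound 3 (0.70 log units; beyond the scatter), whereas chloro gave a 2.2-fold higher number from compound 1 to compound 2 (0.34 log units; beyond the scatter), so the two substituents move the number in opposite directions from hydrogen, and the gain seen with methyl is more than the mere loss of chloro. No supporting measurement accompanies these values to explain why two groups that match in heavy-atom count, and carry no hydrogen-bond donors or acceptors, part so sharply.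

Open, on these data alone, is whether the lower number persists or deepens with a longer chain such as ethyl, or with methoxy, an amine or a carboxylic acid at this same place. Also open, as far as these compounds go, is whether the 4-methylphenyl gain holds when the other phenyl groups on the shared core are changed, since all three compounds keep them fixed.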